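Fluoro removal on the anilide of compound 1

A few compounds are considered here, and "the series" means these few. Any claim that something is new, unique, unknown or untested is made for them only; others in the source may bear on it.

Compound 1, `COc1cc2nc(N3CCC4CCC(C3)N4Cc3ccccc3)nc(Nc3ccc(S(C)(=O)=O)cc3F)c2cc1OC`, is the higher of the two measured compounds in a functional assay on HEK293 cells for agonist activity at Glucose-dependent insulinotropic receptor (Homo sapiens), read by cAMP accumulation, with a stated time of 60 min (a lower number here means a smaller maximal response, a higher number a larger maximal response), giving 44.3%. Compound 2, `COc1cc2nc(OC3CCN(C(=O)OC(C)(C)C)CC3)nc(Nc3ccc(S(C)(=O)=O)cc3F)c2cc1OC`, gives 19.6% in this assay, a number lower by more than the scatter, but compound 2 differs from compound 1 in more than one place, so no single step can be read from the pair. The unmeasured compound 3, `COc1cc2nc(N3CCC4CCC(C3)N4Cc3ccccc3)nc(Nc3ccc(S(C)(=O)=O)cc3)c2cc1OC`, keeps the shared core and the substituted amine of compound 1 and differs only in hydrogen in place of fluoro on an aromatic carbon. Within the data shown here, no measured pair isolates this change, so the expectation rests on compound 1 alone. Compound 3 is expected to give 40%, within 25% to 55%. The step of a number 4.3 percentage points lower from compound 1 to compound 3 (within the scatter) is expected to be small, with no clear direction, and most likely within the scatter.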

Compound 3, largest response reached (Emax), in percent of the reference or control that the assay uses: 23.4%
The estimate for compound 3 lay 16.6 percentage points above the measured number, outside the stated range (below it).
By their numbers in this assay, from the lowest: compounds 2 and 3 (each within the scatter of the next); then compound 1.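

In this assay, among these compounds, replacing fluoro with hydrogen in the 2-fluoro-4-(methylsulfonyl)phenyl group gives a number 20.9 percentage points lower from compound 1 to compound 3 (beyond the scatter) and provides the first single-place step. It shows that this aromatic carbon, ortho to a large group and meta to a methylsulfonyl group, is not indifferent to the substituent it carries: the exchange of one fluorine atom for hydrogen is enough to lower the maximal response. The data shown give no explanation for this step.

Going by these compounds, whether chloro, methyl, methoxy or an amine at this carbon would give a maximal response closer to that of compound 1 or that of compound 3 remains open. Also open, on these data alone, is whether the same exchange would give a similar step with the substituent of compound 2 in place of the substituted amine.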